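Amine side chain variation on the shared core

The source may hold more compounds than are shown below. What is called first, only, known or untested is meant among the compounds shown, and "the series" means these compounds.

In an assay on isolated protein for antagonist activity at advanced glycosylation end product-specific receptor (Homo sapiens), read by ELISA, with a stated time of 60 min, tested at 10 uM (a higher number here means more inhibition at the concentration tested (going by the name of the read-out), a lower number less inhibition), compound 2 `CCCCc1sc(-c2ccc(OCC3CCCN(CC)C3)cc2)nc1-c1ccc(Oc2ccc(Cl)cc2)cc1` gives 58%, the second highest of three numbers; compound 3 `CCCCc1sc(Nc2ccc(OCCCN(CC)CC)cc2)nc1-c1ccc(Oc2ccc(Cl)cc2)cc1` gives 60.9%, within the scatter of compound 2, while compound 1 `CCCCc1sc(-c2ccc(OCCCN3CCCC3)cc2)nc1-c1ccc(Oc2ccc(Cl)cc2)cc1` gives 47.8%, lower beyond the scatter. Compound 4 `CCCCc1sc(-c2ccc(OCCCN3CCCCC3)cc2)nc1-c1ccc(Oc2ccc(Cl)cc2)cc1` is unmeasured. Its difference from compound 2 is 2-(piperidin-1-yl)ethyl in place of 1-ethylpiperidin-3-yl on a saturated chain carbon bound to an oxygen on an aromatic ring. Within the data shown here, the single bearing step runs the opposite way: a number 10.2 percentage points higher from compound 1 to compound 2 (beyond the scatter), where 2-(pyrrolidin-1-yl)ethyl gave way to 1-ethylpiperidin-3-yl. Compound 4 carries 2-(piperidin-1-yl)ethyl, close to what compound 1 carries, so a partial return is expected. The step for compound 4 is estimated at a number 8 percentage points lower from compound 2 to compound 4 (within the scatter), probably near the edge of the scatter. Compound 4 is expected at 50%, range 38% to 62%.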

Compound 4, a percentage reported as inhibition, at one concentration (the size of the read-out at that concentration, not a potency): 59.2%
Compound 4: middle estimate off by 9.2 percentage points, on the low side; measured number inside the range.
By their numbers in this assay, from the lowest: compound 1; then compounds 2, 4 and 3 (each within the scatter of the next).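

In the series read in this assay, the same atoms rearranged from 1-ethylpiperidin-3-yl to 2-(piperidin-1-yl)ethyl on this saturated chain carbon make no clear difference (a number 1.2 percentage points higher from compound 2 to compound 4 (within the scatter)). The lower number of compound 1 therefore does not go with the open chain itself, as piperidin-1-yl in place of pyrrolidin-1-yl separates the two chain-bearing compounds (a number 11.4 percentage points higher from compound 1 to compound 4 (beyond the scatter)). No measurement at hand accounts for this difference.

Still open, going by these compounds, is whether a morpholin-4-yl or a dimethylamino group at the chain end would match compound 4, and what a shorter chain would give.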